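A few compounds are considered here, and "the series" means these few. Any claim that something is new, unique, unknown or untested is made for them only; others in the source may bear on it.

Measured compounds:
compound 1, `Brc1ccc(C2=NN(C3=NC(c4ccccc4)CS3)C(c3ccc4ccccc4c3)C2)cc1`, 4960 nM in a functional assay on HeLa cells (Homo sapiens) for inhibition, read by CCK-8 assay, with a stated time of 48 h; a higher number here means a weaker inhibitor, a lower number a stronger inhibitor
compound 2, `Cc1ccc(C2=NN(C3=NC(c4ccccc4)CS3)C(c3cccc4ccccc34)C2)cc1`, 4290 nM in this assay

Of the compounds shown here, two sharing one core have been tested in this assay. Compound 1 gives 4960 nM and compound 2 gives 4290 nM. Compound 2 has the lower of the two numbers, but the gap to compound 1 is within the usual scatter, so the two cannot be told apart.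

Compound 3, `Brc1ccc(C2=NN(C3=NC(c4ccccc4)CS3)C(c3cccc4ccccc34)C2)cc1`, has not yet been measured. It differs from compound 2 in one place: bromo in place of methyl on an aromatic carbon. Among the measured compounds shown here, since no pair of measured compounds differs only in this way, the size of the step cannot be read from the data. Compound 1 carries the same bromo group together with a different ring attachment and sits close to compound 2, which hints that the change is modest.

Compound 3 is therefore expected to give about 4500 nM, between 2000 nM and 10000 nM. The expected step of a 1.0-fold higher number from compound 2 to compound 3 (0.02 log units; within the scatter) lies within the scatter.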

Compound 3, half-maximal inhibitory concentration: 6650 nM
Beside the measured number, compound 3's estimate is 1.5-fold (0.17 log units) below it; low and high end bracket the measured number.
By their numbers in this assay, from the lowest: compounds 2, 1 and 3 (each within the scatter of the next).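

In this assay, among the compounds shown here, 4-bromophenyl in place of 4-methylphenyl gives a 1.6-fold higher number from compound 2 to compound 3 (0.19 log units; within the scatter), the first direct reading at this position, and at this place on the aromatic ring bromo and methyl cannot be told apart. Moving the attachment of the naphthalene, with naphthalen-1-yl in place of naphthalen-2-yl on a saturated ring carbon, gives a 1.3-fold higher number from compound 1 to compound 3 (0.13 log units; within the scatter), so these two attachments cannot be told apart either. No measurement at hand offers an explanation for these numbers.

The compounds shown cover only methyl and bromo at this position, so it remains open whether a group such as an amine, a carboxylic acid or a longer chain would shift the number beyond the scatter. On these data alone, the effect of changing the unsubstituted phenyl ring on the shared core also remains open.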